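A few compounds are considered here, and "the series" means these few. Any claim that something is new, unique, unknown or untested is made for them only; others in the source may bear on it.

Compound 2 `O=C(Nc1cc(Sc2ncn[nH]2)c(O)c2ccccc12)c1ccc2ccccc2c1` stands higher of the two compounds measured in an assay on isolated protein for inhibition of RAC-alpha serine/threonine-protein kinase (Homo sapiens), read by fluorescence, with a stated time of 30 min, tested at 10 uM (on this read-out higher numbers stand for more inhibition at the one concentration tested (going by the name of the read-out) and lower numbers for less inhibition), where compound 2 gives 41.6%. Among the compounds with values here, its only measured neighbour, compound 1 `O=C(Nc1cc(Sc2ncn[nH]2)c(O)c2ccccc12)c1cccc([N+](=O)[O-])c1`, gives 29.3% in this assay, and the step of a number 12.3 percentage points higher from compound 1 to compound 2 (beyond the scatter) is the single comparison available. Compound 3 `O=C(Nc1cc(Sc2ncn[nH]2)c(O)c2ccccc12)c1cccc(Cl)c1` has not yet been measured. It differs from compound 2 in one place: 3-chlorophenyl in place of naphthalen-2-yl on a carbonyl carbon. This change reverses the kind of move seen in the measured pair: a single six-membered ring again stands where the two rings of naphthalen-2-yl stood, though this time the ring carries chlorine rather than the nitro group of compound 1. Within the data shown here, the one step that bears on the question, a number 12.3 percentage points higher from compound 1 to compound 2 (beyond the scatter), was modest and ran upward when the two-ring group came in, so the return to a single ring is expected to run downward by a similar modest amount, with the untested chlorine widening the uncertainty. Compound 3 is expected to give roughly 32% in this assay, within about 15% to 50%, which corresponds to an expected step of a number 9.6 percentage points lower from compound 2 to compound 3 (within the scatter).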

Compound 3, a percentage reported as inhibition, at one concentration (the size of the read-out at that concentration, not a potency): 46%
Compound 3: middle estimate off by 14 percentage points, on the low side; measured number inside the range.
By their numbers in this assay, from the lowest: compound 1; then compounds 2 and 3 (each within the scatter of the next).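

In this assay, putting 3-chlorophenyl in place of naphthalen-2-yl on the carbonyl carbon gives a number 4.4 percentage points higher from compound 2 to compound 3 (within the scatter), so at this position a single ring carrying chlorine cannot be told apart from the two-ring group. Keeping a single ring and changing only its substituent, chloro in place of nitro on an aromatic carbon, gives a number 16.7 percentage points higher from compound 1 to compound 3 (beyond the scatter), a step beyond the scatter. The earlier comparison could be read as a gain from the second ring, but these three compounds show that the number at this position also depends on what the single ring carries, and that one ring can match two.

Nothing measured on these compounds explains the gap between the chloro and nitro groups. Also open, as far as these compounds go, is how a plain phenyl, or a phenyl bearing a methoxy group or an amine, would read at this position, which would help show whether chlorine raises the number or the nitro group lowers it.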